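Bulkier Ester on a Calcium Channel Blocker Core

This account rests on a few compounds, and the source may have more. Where it says the series, first, only, none or still open, it means among the compounds named here.

Measured compounds:
- compound 1 `CCOC(=O)C1=C(C)NC(C)=C(C(=O)OC)C1c1[nH]cnc1Cl`: 661 nM
- compound 2 `CCCOC(=O)C1=C(C)NC(C)=C(C(=O)OC)C1c1[nH]cnc1Cl`: 437 nM
- compound 3 `COC(=O)C1=C(C)NC(C)=C(C(=O)OCC2CCCCC2)C1c1[nH]cnc1Cl`: 355 nM

In an assay on isolated protein for inhibition of Voltage-dependent L-type calcium channel subunit alpha-1C (Cavia porcellus) (on this read-out lower numbers stand for stronger inhibition and higher numbers for weaker inhibition), compound 1 gives the highest of the three numbers, yet both neighbours lie within the scatter: a 1.5-fold lower number from compound 1 to compound 2 (0.18 log units; within the scatter) and a 1.9-fold lower number from compound 1 to compound 3 (0.27 log units; within the scatter). Compound 4 `CCOC(=O)C1=C(C)NC(C)=C(C(=O)OC(C)(C)C)C1c1[nH]cnc1Cl` is not yet measured; it differs from compound 1 by tert-butyl in place of methyl on an oxygen next to a carbonyl group. Both measured steps enlarge an ester group on the same core, so they bear on this change, and each gave only a modest lowering of the number. The step from compound 2 to compound 3 is smaller still, a 1.2-fold lower number from compound 2 to compound 3 (0.09 log units; within the scatter). A comparable small lowering is therefore expected in this assay, a 1.5-fold lower number from compound 1 to compound 4 (0.17 log units; within the scatter), not clearly beyond the scatter. Compound 4 is estimated at 450 nM, within 200 nM to 1000 nM.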

Compound 4, half-maximal inhibitory concentration: 1660 nM
Compound 4: middle estimate off by 3.7-fold (0.57 log units), on the low side; the whole stated range lies below it.
By their numbers in this assay, from the lowest: compounds 3, 2 and 1 (each within the scatter of the next); then compound 4.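

Placing tert-butyl directly on the ester oxygen reverses the direction seen so far, giving a 2.5-fold higher number from compound 1 to compound 4 (0.40 log units; beyond the scatter), the first step here beyond the scatter. Compounds 2 and 3 also carry larger ester groups, but their added carbons lie further out along the chain, and their steps from compound 1 stay within the scatter, so a larger ester alone does not raise the number. Nothing measured here explains this difference.

On these data alone, whether the rise needs the full tert-butyl remains open. Isopropyl or n-butyl on this same oxygen could separate branching from chain length.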